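A phenyl group exchanged on compound 2

The source may hold more compounds than are shown below. What is called first, only, known or untested is meant among the compounds shown, and "the series" means these compounds.

In an ADME assay on a cell-free system (plasma, Rattus norvegicus) for metabolic stability, read by LC-MS, with a stated time of 1 h, at 37 degrees C, tested at 100 uM (a higher number here means that more of the compound is left, a lower number that less of the compound is left), compound 2 `O=C1c2ccc(OCc3cccc(-c4ccccc4)c3)cc2CN1C1CCCC1` gives 95% and compound 3 `CN(C)C(=O)c1cc(-c2cccc(COc3ccc4c(=O)n(C5CCCC5)sc4c3)c2)ccc1Cl` gives 100%, so the two stand within the scatter of each other. Compound 1 `O=C1c2ccc(OCc3cccc(-c4ccc(Cl)cc4F)c3)cc2CN1C1CCCC1` offers no number for comparison, its entry reading "not determined" (no result reported). Compound 4 `COc1ccc(C(=O)O)cc1-c1cccc(COc2ccc3c(c2)CN(C2CCCC2)C3=O)c1` comes from compound 2 through one change, (5-carboxy-2-methoxyphenyl in place of phenyl on an aromatic carbon), with 5-carboxy-2-methoxyphenyl in place of phenyl on an aromatic carbon. Within the data shown here, no measured pair shows the size of such a change. With compound 2 at 95% and compound 3 at 100%, no step beyond the scatter is expected in this assay. The estimated step is no change at the digits printed from compound 2 to compound 4 (within the scatter). For compound 4, the expected value is 95%, within an estimated range of 85% to 100%.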

Compound 4, percent of the compound remaining: 100%
Estimate against measurement, compound 4: 5 percentage points below; the range from low to high includes it.
By their numbers in this assay, from the lowest: compounds 2, 3 and 4 (each within the scatter of the next).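

In this assay, among these compounds, the exchange of phenyl for 5-carboxy-2-methoxyphenyl gives a number 5 percentage points higher from compound 2 to compound 4 (within the scatter) and so offers the first reading of a step at this aromatic carbon, meta to a large group. The entering group carries a hydrogen-bond donor and hydrogen-bond acceptors that phenyl lacks, yet the step stays within the scatter. The compounds shown leave open how the carboxylic acid and the methoxy group each read alone, and how an amine or a longer chain at this place would read. Nothing at hand explains the result.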